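Shortening a Butylamide Chain on an Indole-Bearing Core

The source may hold more compounds than are shown below. What is called first, only, known or untested is meant among the compounds shown, and "the series" means these compounds.

Measured compounds:
compound 1, `CCC1C(=O)N(C)c2cnc(Nc3ccc(S(=O)(=O)NC)cc3)nc2N1c1ccn(C)n1`, 3750 nM in a functional assay on MCF7 cells (Homo sapiens) for antiproliferative activity, read by CCK-8 assay, with a stated time of 72 h; a lower number here means a stronger inhibitor of growth, a higher number a weaker inhibitor of growth
compound 2, `CCCNS(=O)(=O)c1ccc(Nc2ncc3c(n2)N(c2ccn(C)n2)C(CC)C(=O)N3C)cc1`, 3000 nM
compound 3, `CCCCNC(=O)c1ccc2c(ccn2-c2ncc3c(n2)N(c2ccn(C)n2)C(CC)C(=O)N3C)c1`, 8990 nM

Compound 1 and compound 2 share a core and differ only by hydrogen in place of ethyl on a saturated chain carbon bound to a sulfonamide nitrogen; this gave a 1.3-fold higher number from compound 2 to compound 1 (0.10 log units; within the scatter). Compound 3 carries a different core, and the difference between the two cores is not broken down here; its value stands beyond the scatter from both compound 1 and compound 2.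

Compound 4, `CCNC(=O)c1ccc2c(ccn2-c2ncc3c(n2)N(c2ccn(C)n2)C(CC)C(=O)N3C)c1`, is not yet measured. It differs from compound 3 by hydrogen in place of ethyl on a saturated chain carbon, two bonds along the chain from an amide-type nitrogen. This is the same kind of change as from compound 2 to compound 1, but not the same: there the carbon was bound to a sulfonamide nitrogen, here it lies two bonds along the chain from an amide-type nitrogen. Because a 1.3-fold higher number from compound 2 to compound 1 (0.10 log units; within the scatter) was small, a similarly small step is expected for compound 4, a 1.1-fold higher number from compound 3 to compound 4 (0.05 log units; within the scatter). Compound 4 is therefore estimated at 10000 nM in this assay, between 4500 nM and 22000 nM.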

Compound 4, concentration for 50% growth inhibition: 13200 nM
Beside the measured number, compound 4's estimate is 1.3-fold (0.12 log units) below it; measured number inside the range.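

In this assay, changing butyl to ethyl gave a 1.5-fold higher number from compound 3 to compound 4 (0.17 log units; within the scatter), so the change had no effect that can be told from the scatter. The same change on the other core gave a matching result: the same change on two cores in this assay, a 1.3-fold higher number (0.10 log units; within the scatter) from compound 2 to compound 1 and a 1.5-fold higher number (0.17 log units; within the scatter) from compound 3 to compound 4, 1.2-fold (0.07 log units) apart, within the scatter of two such steps. Going by these compounds alone, this shows only that the change left the number within the scatter on these two cores; it shows no direction, and two pairs cannot establish that the same would hold on any further core.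

The compounds shown leave open how a chain longer than butyl would fare on either core. They also leave open what an amine or a carboxylic acid in place of the chain would do.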